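The source may hold more compounds than are shown below. What is called first, only, known or untested is meant among the compounds shown, and "the series" means these compounds.

Measured compounds:
compound 1 `CCc1cccc(CC)c1NC(=O)NCC1(c2ccccc2)CCCCC1`, 51 nM
compound 2 `Cc1cccc(C(C)C)c1NC(=O)NCC1(c2ccccc2)CCCCC1`, 58 nM

In an assay on microsomes from intestine for inhibition of acyl-CoA:cholesterol acyltransferase (Oryctolagus cuniculus) (on this read-out lower numbers stand for stronger inhibition and higher numbers for weaker inhibition), compound 1 gives 51 nM and compound 2 gives 58 nM. Compound 2 holds the higher of the two numbers, but the gap to compound 1 lies within the scatter, so the two read as equivalent.

Compound 3 `CCc1cccc(C(C)C)c1NC(=O)NCC1(c2ccccc2)CCCCC1` is not yet measured. It differs from compound 2 by methyl in place of hydrogen on a saturated chain carbon bound to an aromatic carbon. Within the data shown here, with only two equivalent values to go on, no step beyond the scatter is expected in this assay in either direction. Compound 3 is expected at 50 nM, with a range of 25 nM to 100 nM. The step of a 1.2-fold lower number from compound 2 to compound 3 (0.06 log units; within the scatter) is thus estimated to stay within the scatter.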

Compound 3, half-maximal inhibitory concentration: 20 nM
The estimate for compound 3 lay 2.5-fold (0.40 log units) above the measured number, outside the stated range (below it).
By their numbers in this assay, from the lowest: compound 3; then compounds 1 and 2 (each within the scatter of the next).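

In this assay the change of methyl to ethyl gives a 2.9-fold lower number from compound 2 to compound 3 (0.46 log units; beyond the scatter) and so opens a step beyond the scatter that the first two values did not show. Methyl in place of hydrogen on a saturated chain carbon bound to an aromatic carbon and a saturated chain carbon gives a 2.6-fold lower number from compound 1 to compound 3 (0.41 log units; beyond the scatter) and points the same way. Ethyl and isopropyl occur together only in compound 3, the one compound of the three set apart by a step beyond the scatter.

Going by these compounds, whether a longer chain, tert-butyl or an amine at this place would extend or reverse the step remains open. Nothing at hand gives a cause for either step.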